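Chalcone-pyrazole series: methoxy removal on the pyrazole-linked ring

The compounds below may be only part of what the source reports. "The series", "measured", "known", "first", "only" and "open" are said of these compounds alone.

Measured so far:
compound 1 `COc1ccc(-c2cc(/C=C/C(=O)c3ccc(N)cc3)[nH]n2)cc1` — 71%
compound 2 `COc1ccc(-c2cc(/C=C/C(=O)c3ccc(N)cc3)[nH]n2)cc1OC` — 88%
compound 3 `COc1cc(C(=O)/C=C/c2cc(-c3cc(OC)c(OC)c(OC)c3)n[nH]2)cc(OC)c1OC` — 89%

In a functional assay on ACHN cells (Homo sapiens) for cytotoxicity, read by sulforhodamine B assay, with a stated time of 48 h, tested at 1 uM (a higher number here means a weaker effect of the compound at the concentration tested, a lower number a stronger effect), compound 2 gives 88% and compound 1 gives 71%; the step is a number 17 percentage points lower from compound 2 to compound 1 (beyond the scatter), and the change is hydrogen in place of methoxy on an aromatic carbon. Compound 3, in this assay at 89%, sits within the scatter of compound 2; how the cores of compound 2 and compound 3 differ is not broken down here.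

Compound 4 `COc1ccc(-c2cc(/C=C/C(=O)c3cc(OC)c(OC)c(OC)c3)[nH]n2)cc1OC` has yet to be tested in this assay. It is made from compound 3 by hydrogen in place of methoxy on an aromatic carbon — the same kind of change as from compound 2 to compound 1, though here the place is also meta to a methoxy group. Resting on the one earlier step, a similar but somewhat smaller move is expected: a number 11 percentage points lower from compound 3 to compound 4 (beyond the scatter). The estimate for compound 4 is 78%, between 60% and 92%.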

Compound 4, a percentage reported as activity, at one concentration (the size of the read-out at that concentration, not a potency): 78%
For compound 4 middle estimate and measured number coincide at the digits printed, within the range that was stated.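

In this assay, hydrogen in place of methoxy on an aromatic carbon gives a number 11 percentage points lower from compound 3 to compound 4 (beyond the scatter), so the change carries to a second core in the same direction and with a size not distinguishable from the earlier step: the same change on two cores in this assay, a number 17 percentage points lower (beyond the scatter) from compound 2 to compound 1 and a number 11 percentage points lower (beyond the scatter) from compound 3 to compound 4, 6 percentage points apart, within the scatter of two such steps. Among these compounds, this rests on only two pairs, each changed at a single place on its own core, so it gives no general rule for the series. The read-out comes from one concentration, so it says nothing about potency, and the two steps do not explain why the number drops.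

Methoxy and hydrogen are the only groups compared at this place. On these data alone, how a hydroxyl, a fluorine or a longer ethoxy chain would behave there remains open.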